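The compounds below may be only part of what the source reports. "The series", "measured", "known", "first", "only" and "open" are said of these compounds alone.

Working notes on the series. The set so far holds two measured compounds. Compound 1 `OC[C@]1(c2cccc(F)c2)NC[C@H](O)[C@H]1O` carries an aryl group on the shared core; in an assay on isolated protein for inhibition of lysosomal alpha-glucosidase (Homo sapiens) (a higher number here means a weaker inhibitor, a lower number a stronger inhibitor), compound 1 gives 491000 nM. Compound 2 `C[C@@]1(CO)NC[C@H](O)[C@H]1O`, with a methyl in place of that aryl group, gives in this assay a value of 5600 nM. Compound 2 therefore stands at the lowest of the two numbers shown, the gap to compound 1 lying well beyond the scatter. The next compound, compound 3 `C[C@]1(CO)NC[C@@H](O)[C@@H]1O`, is built from compound 2 by a change in configuration alone: the two compounds have the same atoms and bonds and differ only in configuration as drawn: 3 of 3 stereo elements differ (all stereocentres are inverted: mirror images); a stereocentre at a saturated ring carbon is drawn S in compound 2 and R in compound 3; a stereocentre at a saturated ring carbon is drawn S in compound 2 and R in compound 3; a stereocentre at a saturated ring carbon is drawn S in compound 2 and R in compound 3. Going by the values given here, no step between measured compounds in this set tells what such an inversion of all stereocentres does, so the direction rests on the general behaviour of mirror images in this assay: the expected step from compound 2 to compound 3 is an 18-fold higher number from compound 2 to compound 3 (1.25 log units; beyond the scatter), towards a weaker inhibitor, with wide uncertainty about its size. Compound 3 is accordingly expected to give about 100000 nM, the estimate ranging from 10000 nM to 1000000 nM.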

Compound 3, half-maximal inhibitory concentration: 16000 nM
For compound 3 the middle estimate is 6.3-fold (0.80 log units) above the measured one; the measured number falls inside the stated range.
By their numbers in this assay, from the lowest: compound 2; then compound 3; then compound 1.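

Inversion of all stereocentres gives the first step in the series that can be read at a single change: in this assay it produces a 2.9-fold higher number from compound 2 to compound 3 (0.46 log units; beyond the scatter). The step is modest but beyond the scatter, so this assay distinguishes the two mirror images, and the inversion does not remove measurable inhibition, since compound 3 still gives 16000 nM. No group enters or leaves along this step, so the shift in the number can be assigned to configuration alone, because of this: the fact that compounds 2 and 3 differ only in the configuration as drawn

With all stereocentres changing together, the compounds shown do not separate the contribution of any one stereocentre from that of the others, so it remains open whether the step comes mainly from one centre or is shared among them. Also open, from the compounds shown here alone, is whether the same inversion would give a step of similar size and direction with another group in place of the methyl, such as an ethyl, a longer chain or an amine-bearing chain.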